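The source may report more compounds than this note shows. Statements on the series, on what has been measured and on what is new or still open speak of the compounds shown alone.

Measured compounds:
Compound 1 `O=C(C(Nc1ccccc1F)c1ccc(C(F)(F)F)cc1)N1CCCC1c1ccccc1F`, which in an assay on HEK293 cells for antagonist activity at transient receptor potential M8 protein (Canis lupus familiaris), read by fluorescence and calcium flux, with a stated time of 5 min (a lower number here means a stronger inhibitor, a higher number a weaker inhibitor), gives 7 nM.
Compound 2 `O=C(O)c1cccc(C2CCCN2C(=O)C(Nc2ccccc2F)c2ccc(C(F)(F)F)cc2)c1`, which in this assay gives 40 nM.

Compound 2 stands at the higher of the two numbers in this assay; its nearest neighbour is compound 1, and the step of a 5.7-fold higher number from compound 1 to compound 2 (0.76 log units; beyond the scatter) lies beyond the scatter, so compound 2 is the weaker inhibitor of the pair.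

Compound 3 `O=C(O)c1ccc(C2CCCN2C(=O)C(Nc2ccccc2F)c2ccc(C(F)(F)F)cc2)cc1` has not yet been measured in this assay. It differs from compound 2 in one place: 4-carboxyphenyl in place of 3-carboxyphenyl on a saturated ring carbon. Among the measured compounds shown here, the only measured step, a 5.7-fold higher number from compound 1 to compound 2 (0.76 log units; beyond the scatter), concerns the arrival of a carboxyphenyl group on this saturated ring carbon and shows that such a group is tolerated at a modest cost; it says nothing about where the acid sits on that ring. For the measured compounds named here, no measured pair compares a 3-carboxyphenyl with a 4-carboxyphenyl, so the direction of the present step cannot be read from the data. The writer therefore expects compound 3 to land near compound 2, whose value is 40 nM, with the step of a 1.3-fold higher number from compound 2 to compound 3 (0.10 log units; within the scatter) expected to stay within or only just beyond the scatter. Compound 3 is estimated at 50 nM, in the range 15 nM to 200 nM.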

Compound 3, half-maximal inhibitory concentration: 66 nM
Beside the measured number, compound 3's estimate is 1.3-fold (0.12 log units) below it, and the stated range covers the measured number.
By their numbers in this assay, from the lowest: compound 1; then compounds 2 and 3 (each within the scatter of the next).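

Among the compounds shown here, compound 3 gives the first comparison of where the acid sits on the aryl group on this saturated ring carbon, next to the ring nitrogen, and in this assay the exchange of 3-carboxyphenyl for 4-carboxyphenyl (a 1.7-fold higher number from compound 2 to compound 3 (0.22 log units; within the scatter)) does not separate the two compounds, which have the same atoms joined differently. Compound 1 now stands apart from both acids, since the second comparison (a 9.4-fold higher number from compound 1 to compound 3 (0.97 log units; beyond the scatter)) lies beyond the scatter, as does the first (a 5.7-fold higher number from compound 1 to compound 2 (0.76 log units; beyond the scatter)), so among these compounds the higher number with a carboxyphenyl group is seen with the acid in either of these two placements. Nothing in the material shown accounts for these numbers.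

The compounds shown leave open whether a methyl ester, a primary amide or an amine carried on the same phenyl ring would stand nearer to compound 1 or nearer to the two acids. They also leave open whether an acid joined to that ring through a longer chain would fall within the scatter of compound 2 and compound 3.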